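This account rests on a few compounds, and the source may have more. Where it says the series, first, only, none or still open, it means among the compounds named here.

In a functional assay on MCF7 cells (Homo sapiens) for antiproliferative activity, with a stated time of 72 h (a lower number here means a stronger inhibitor, a higher number a weaker inhibitor), compound 1 `COc1ccccc1/C=C/c1nc(Nc2ccccc2Cl)c2ccccc2n1` gives 18900 nM and compound 2 `COc1ccccc1/C=C/c1nc(Nc2ccc(O)cc2)c2ccccc2n1` gives 8290 nM, while compound 3 `COc1ccccc1/C=C/c1nc(Nc2cccc(O)c2)c2ccccc2n1` gives 11200 nM in the same read-out. Compound 3 sits within the scatter of both others, with a 1.4-fold higher number from compound 2 to compound 3 (0.13 log units; within the scatter) and a 1.7-fold lower number from compound 1 to compound 3 (0.23 log units; within the scatter) as its steps. Compound 4 `COc1ccc(/C=C/c2nc(Nc3cccc(O)c3)c3ccccc3n2)cc1` differs by 4-methoxyphenyl in place of 2-methoxyphenyl on a double-bonded chain carbon bound to a double-bonded chain carbon on the same core. For the measured compounds named here, no measured step touches this group. The steps measured on a nitrogen on an aromatic ring stay small, and even a 2.3-fold lower number from compound 1 to compound 2 (0.36 log units; beyond the scatter) counts as modest. No step beyond the scatter is therefore expected in this assay here, and the estimated step is a 1.1-fold lower number from compound 3 to compound 4 (0.05 log units; within the scatter) with wide uncertainty. Compound 4 is estimated at 10000 nM within an expected range of 4000 nM to 25000 nM for now.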

Compound 4, half-maximal inhibitory concentration: 14700 nM
Compound 4: the middle estimate sits 1.5-fold (0.17 log units) below what was measured, and the stated range covers the measured number.
By their numbers in this assay, from the lowest: compounds 2, 3, 4 and 1 (each within the scatter of the next, the first and the last beyond it).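

For the compounds shown here, at the place on a double-bonded chain carbon bound to a double-bonded chain carbon, 4-methoxyphenyl in place of 2-methoxyphenyl gives a 1.3-fold higher number from compound 3 to compound 4 (0.12 log units; within the scatter) in this assay as the first measured change here. With the 3-hydroxyphenyl group on the nitrogen held constant, this read-out does not separate these two methoxyphenyl groups. No available measurement bears on this result.

As far as these compounds go, what an amine or a carboxylic acid in place of the methoxy group would do remains open. Also open, from the compounds shown here alone, is whether the two methoxyphenyl groups stay alike with 4-hydroxyphenyl or 2-chlorophenyl on the nitrogen.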